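This account rests on a few compounds, and the source may have more. Where it says the series, first, only, none or still open, it means among the compounds named here.

Of the compounds shown here, two have been measured in a functional assay on DLD-1 cells (Homo sapiens) for antiproliferative activity, read by CellTiter-Glo, with a stated time of 72 h (on this read-out lower numbers stand for stronger inhibition and higher numbers for weaker inhibition), so far. Compound 1, `COc1ccc(-c2cccc(S(=O)(=O)N3CCC(N4CCC(C)CC4)CC3)c2)cc1`, gives 23 nM. Among the compounds with values here, compound 2, `CC1CCN(C2CCN(S(=O)(=O)c3cccc(-c4ccccc4F)c3)CC2)CC1`, gives 10 nM, the lower of the two numbers, with compound 1 its only neighbour; the change from one to the other was a 2.3-fold lower number from compound 1 to compound 2 (0.36 log units; beyond the scatter). Compound 3, `CC1CCN(C2CCN(S(=O)(=O)c3cccc(-c4ccc5ccccc5c4)c3)CC2)CC1`, is not yet measured. It differs from compound 2 in one place: naphthalen-2-yl in place of 2-fluorophenyl on an aromatic carbon. Within the data shown here, the only step that touches this position is the one from compound 1 to compound 2, and it was modest, so the aryl group at this position has so far moved the number only a little. For compound 3 the expectation is therefore a step of about a 1.5-fold higher number from compound 2 to compound 3 (0.18 log units; within the scatter), that is little change beyond the scatter in either direction. Compound 3 is estimated at 15 nM, with a range from 4 nM to 60 nM.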

Compound 3, half-maximal inhibitory concentration: 2 nM
Beside the measured number, compound 3's estimate is 7.5-fold (0.88 log units) above it; measured number outside the range, below it.
By their numbers in this assay, from the lowest: compound 3; then compound 2; then compound 1.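

This position tolerates more than a single substituted benzene ring. In this assay, within the data shown here, the fused pair of carbon rings of naphthalen-2-yl gives a 5.0-fold lower number from compound 2 to compound 3 (0.70 log units; beyond the scatter) and is the first change here to reach a large step, with a 12-fold lower number from compound 1 to compound 3 (1.06 log units; beyond the scatter) making compound 3 the strongest inhibitor of the three, so the aryl group on this aromatic carbon can matter more than the first pair suggested. Nothing available explains why the number falls.

Since each aryl group here differs from the others in more than one feature, these compounds cannot show whether the second fused ring itself drives the gain. An unsubstituted phenyl, naphthalen-1-yl or a quinoline ring carrying a nitrogen atom at this position would help separate ring size from the way the rings are attached.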